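A few compounds are considered here, and "the series" means these few. Any claim that something is new, unique, unknown or untested is made for them only; others in the source may bear on it.

In a functional assay on A549 cells (Homo sapiens) for antiproliferative activity, read by trypan blue exclusion, with a stated time of 24 h (on this read-out lower numbers stand for stronger inhibition and higher numbers for weaker inhibition), compound 1 `O=C1NC(=O)/C(=C/c2cn(Cc3ccccc3)c3ccccc23)N1` gives > 40000 nM, which is a limit of the assay and not a number. The position of compound 1 is therefore known only as a limit, and the limit of > 40000 nM in this assay, at which 1 of the 2 values shown sits, shows how little of the series can yet be read as exact values. Compound 2 `O=C1NC(=O)/C(=C/c2cn(Cc3ccccc3Br)c3ccccc23)N1` carries a bromo in place of hydrogen on an aromatic carbon, and compound 2 gives 39500 nM. Among the measured compounds shown here, this single measured step, an at least 1.0-fold lower number from compound 1 to compound 2 (0.00 log units; that floor lies within the scatter), is the only guide available, and it was made at a different place from the change now in question.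

Compound 3 `Cc1ccc2c(c1)c(/C=C1\NC(=O)NC1=O)cn2Cc1ccccc1` departs from compound 1 through methyl in place of hydrogen on an aromatic carbon: a methyl in place of hydrogen on an aromatic carbon. For the measured compounds named here, no step beyond the scatter is expected in this assay because the one measured substitution on compound 1 gave an at least 1.0-fold lower number from compound 1 to compound 2 (0.00 log units; that floor lies within the scatter) and the direction of any change remains open. For compound 3 the expected half-maximal inhibitory concentration is 38000 nM, with an estimated range from 15000 nM to 60000 nM. The estimated step is an at least 1.0-fold lower number from compound 1 to compound 3 (0.02 log units; that floor lies within the scatter).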

Compound 3, half-maximal inhibitory concentration: 27700 nM
The estimate for compound 3 lay 1.4-fold (0.14 log units) above the measured number; the range from low to high includes it.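

Among the compounds shown here, with the methyl on an aromatic carbon of a six-membered aromatic ring of carbon only, part of a fused or bridged system of two rings, the series gains a reading in this assay at a place other than the one changed in compound 2, and the step reads an at least 1.4-fold lower number from compound 1 to compound 3 (0.15 log units; that floor lies within the scatter). Even here, where one hydrogen gives way to a methyl of a single carbon, the printed floor stays within the scatter, so the change cannot be claimed as a real gain, nor can it be dismissed as having no effect. The true size of the step stays unknown because compound 1 stands only as a limit, and the series still rests partly on that limit: the limit of > 40000 nM in this assay, at which 1 of the 3 values shown sits.

The compounds shown leave open whether a different group at this same place, such as a methoxy, an amine or a carboxylic acid, would move the number beyond the scatter. They also leave open whether a methyl on another carbon of this ring would read any differently from compound 3.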